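Trimming One Methoxy from Compound 1

This account rests on a few compounds, and the source may have more. Where it says the series, first, only, none or still open, it means among the compounds named here.

Compound 1 `COc1cc(C2=CC(c3cc(OC)c(OC)c(OC)c3)NC(=S)N2)cc(OC)c1OC` gives > 100000 nM in a functional assay on B16 cells (Mus musculus) for cytotoxicity, read by MTT assay, with a stated time of 72 h; on this read-out lower numbers stand for stronger inhibition and higher numbers for weaker inhibition.
Compound 2 `COc1cc(OC)c(C2C=C(c3cc(OC)c(OC)c(OC)c3)NC(=S)N2)c(OC)c1` gives 6300 nM in this assay.

Compound 1 therefore stands at a limit of this assay and not at a number, as shown by the limit of > 100000 nM in this assay, at which 1 of the 2 values shown sits. Compound 2 returns a number. For the measured compounds named here, the two measured compounds do not differ in a single place, so no measured step fixes how large a change of one group can be; what the two values show is that one compound sits at the limit and the other does not.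

Compound 3 `COc1ccc(C2C=C(c3cc(OC)c(OC)c(OC)c3)NC(=S)N2)cc1OC` differs from compound 1 by hydrogen in place of methoxy on an aromatic carbon. Since compound 1 offers only a limit, the step can only be guessed. A modest gain in potency is expected, with a step of an at least 2.0-fold lower number from compound 1 to compound 3 (0.30 log units; that floor lies within the scatter). Compound 3 is estimated at 50000 nM in this assay, likely between 12000 nM and 200000 nM, with a fair chance that only a limit is reported again.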

Compound 3, half-maximal inhibitory concentration: > 100000 nM
Compound 3: a limit, no number; the forecaster's own chance of this, stated with the estimate: 45%; middle value at least 2.0-fold (0.30 log units) from the limit.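

For the compounds shown here, compound 1 and compound 3 both stand at a limit of this assay and not at a number, so no step between them can be read: the limit of > 100000 nM in this assay, at which 2 of the 3 values shown sit.

In this assay the compounds shown leave open how large the effect of hydrogen in place of methoxy on an aromatic carbon is.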